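Swapping the Aryl Group on a Fused Core

The source may hold more compounds than are shown below. What is called first, only, known or untested is meant among the compounds shown, and "the series" means these compounds.

Going by the values given here, compound 3 `Fc1ccccc1-c1cn2ccnc2c(-c2ccc3ncn(C4CCCCC4)c3c2)n1` gives 16.3% in a functional assay on SR cells (Homo sapiens) for inhibition, read by sulforhodamine B assay, with a stated time of 48 h, tested at 10 uM (on this read-out lower numbers stand for less inhibition and higher numbers for more inhibition at the one concentration tested (going by the name of the read-out)), the lowest of the three numbers measured so far. Compound 2 `Fc1ccc(-c2cn3ccnc3c(-c3ccc4ncn(C5CCCCC5)c4c3)n2)cc1` gives 20.4%, and compound 1 `Brc1cn2ccnc2c(-c2ccc3ncn(C4CCCCC4)c3c2)n1` gives 26.8%. The step of a number 10.5 percentage points lower from compound 1 to compound 3 (beyond the scatter) lies beyond the scatter, while a number 4.1 percentage points lower from compound 2 to compound 3 (within the scatter) and a number 6.4 percentage points lower from compound 1 to compound 2 (within the scatter) both lie within it. Compound 4 `FC(F)(F)c1cccc(-c2cn3ccnc3c(-c3ccc4ncn(C5CCCCC5)c4c3)n2)c1` carries a further exchange of the same kind: 3-(trifluoromethyl)phenyl in place of 2-fluorophenyl on an aromatic carbon. The step that bears most closely on this change is a number 4.1 percentage points lower from compound 2 to compound 3 (within the scatter), where one fluorophenyl group gave way to another and the number hardly moved. A third substituted phenyl in this position is therefore expected to bring only a small shift, estimated as a number 1.7 percentage points higher from compound 3 to compound 4 (within the scatter). Compound 4 is expected to give about 18%, within a range from 5% to 32%.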

Compound 4, a percentage reported as inhibition, at one concentration (the size of the read-out at that concentration, not a potency): 15.6%
The estimate for compound 4 lay 2.4 percentage points above the measured number, within the range that was stated.
By their numbers in this assay, from the lowest: compounds 4, 3, 2 and 1 (each within the scatter of the next, the first and the last beyond it).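

In this assay, the larger 3-(trifluoromethyl)phenyl group cannot be told apart from either fluorophenyl group: a number 0.7 percentage points lower from compound 3 to compound 4 (within the scatter) and a number 4.8 percentage points lower from compound 2 to compound 4 (within the scatter) both stay small. The exchange for bromo does pass the scatter, with a number 11.2 percentage points lower from compound 1 to compound 4 (beyond the scatter), as it did for 2-fluorophenyl but not for 4-fluorophenyl. No measurement available here explains why these numbers sit so close together.

Every aryl group shown is a carbon-only ring bearing fluorine, so it remains open whether an amine or a carboxylic acid on that ring would move the number.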